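This account rests on a few compounds, and the source may have more. Where it says the series, first, only, none or still open, it means among the compounds named here.

Measured compounds:
Compound 1 `OC(CCn1nc2c(Br)c(Br)c(Br)c(Br)c2n1)c1ccc(F)cc1` — in a functional assay on CCRF-CEM cells (Homo sapiens) for antiproliferative activity, read by MTT assay, with a stated time of 24 h, tested at 100 uM (on this read-out higher numbers stand for a weaker effect at the one concentration tested and lower numbers for a stronger effect), compound 1 gives 0%.
Compound 2 `COc1cccc(C(O)CCn2nc3c(Br)c(Br)c(Br)c(Br)c3n2)c1` — in this assay compound 2 gives 48%.
Compound 3 `OC(CCn1nc2c(Br)c(Br)c(Br)c(Br)c2n1)c1cccc(Cl)c1` — in this assay compound 3 gives 0%.

Going by the values given here, compound 3 sits level with compound 1 at the digits printed, the two of them together forming the lowest pair of the three numbers; its only distant neighbour is compound 2, which stands higher by a number 48 percentage points lower from compound 2 to compound 3 (beyond the scatter) read in reverse. Among the steps, moving from compound 1 to compound 3 gave no change at the digits printed from compound 1 to compound 3 (within the scatter), whereas moving from compound 1 to compound 2 gave a number 48 percentage points higher from compound 1 to compound 2 (beyond the scatter).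

Compound 4 `OC(CCn1nc2c(Br)c(Br)c(Br)c(Br)c2n1)c1ccc(Br)cc1` differs from compound 3 by 4-bromophenyl in place of 3-chlorophenyl on a saturated chain carbon bound to an oxygen on a saturated carbon and a saturated chain carbon. Among the compounds with values here, the step that bears on this is the one from compound 1 to compound 3, where one halogen-substituted phenyl replaced another and the read-out was unchanged within the scatter. The large steps both involve compound 2 and its methoxyphenyl, which does not enter here. The account therefore expects a number 5 percentage points higher from compound 3 to compound 4 (within the scatter), no change beyond the scatter, and compound 4 is estimated at 5% with a range from 0% to 25%.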

Compound 4, a percentage reported as activity, at one concentration (the size of the read-out at that concentration, not a potency): 0%
Compound 4: the middle estimate sits 5 percentage points above what was measured, within the range that was stated.
By their numbers in this assay, from the lowest: compounds 1, 3 and 4 (each within the scatter of the next); then compound 2.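

In this assay, 4-bromophenyl in place of 3-chlorophenyl on this saturated chain carbon gives no change at the digits printed from compound 3 to compound 4 (within the scatter) and bromo in place of fluoro on an aromatic carbon gives no change at the digits printed from compound 1 to compound 4 (within the scatter) and thus the read-out holds across three halogen-bearing phenyl groups, now including a change of both the halogen and its place on the phenyl. The change from 3-methoxyphenyl to 4-bromophenyl gives a number 48 percentage points lower from compound 2 to compound 4 (beyond the scatter) and leaves compound 2 as the only one of the four set apart, also the only one with no halogen on its phenyl. Nothing available here accounts for this difference.

As far as these compounds go, it remains open whether the higher number belongs to methoxy alone or would also appear with 4-methoxyphenyl. The same question stands for other non-halogen groups on the phenyl, such as an amine or a carboxylic acid.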